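Adding a Ring Hydroxy Group: What Cytotoxicity to Expect

The source may hold more compounds than are shown below. What is called first, only, known or untested is meant among the compounds shown, and "the series" means these compounds.

Measured compounds:
compound 1 `CCCCCCCCCCC#Cc1cc2cn([C@@H]3O[C@H](CO)[C@@H](O)[C@@H]3O)c(=O)nc2o1`: 116000 nM
compound 2 `CCCCCCCCCCC#Cc1cc2cn([C@H]3C[C@H](O)[C@@H](CO)O3)c(=O)nc2o1`: 36000 nM
compound 3 `CCCCCCCCC#Cc1cc2cn([C@H]3C[C@H](O)[C@@H](CO)O3)c(=O)nc2o1`: 77000 nM

All three were tested in a functional assay on HEL cells (Homo sapiens) for cytotoxicity; a lower number here means that less compound is tolerated, a higher number that more compound is tolerated. Compound 4 `CCCCCCCCC#Cc1cc2cn([C@@H]3O[C@H](CO)[C@@H](O)[C@H]3O)c(=O)nc2o1` has not yet been measured there. Compound 3 differs from compound 2 only in the chain, (hydrogen in place of ethyl on a saturated chain carbon, eight bonds along the chain from a triple-bonded carbon), which gave a 2.1-fold higher number from compound 2 to compound 3 (0.33 log units; beyond the scatter). Compound 1 differs from compound 2 by hydroxy in place of hydrogen on a saturated ring carbon, and this gave a 3.2-fold higher number from compound 2 to compound 1 (0.51 log units; beyond the scatter). Compound 4 carries the same change relative to compound 3, (hydroxy in place of hydrogen on a saturated ring carbon), at the same place and in the same surroundings. Because a 3.2-fold higher number from compound 2 to compound 1 (0.51 log units; beyond the scatter) was seen for this change, a step of about the same size is expected, so that a 3.1-fold higher number from compound 3 to compound 4 (0.49 log units; beyond the scatter) is the estimated step. Compound 4 is therefore expected to give about 240000 nM in this assay, estimated to lie between 120000 nM and 480000 nM.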

Compound 4, half-maximal cytotoxic concentration: 62000 nM
Estimate against measurement, compound 4: 3.9-fold (0.59 log units) above; measured number outside the range, below it.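

In this assay the added ring hydroxy gave a 1.2-fold lower number from compound 3 to compound 4 (0.09 log units; within the scatter), so no real change appears on this core. The two cores respond differently to the same change, and the size of the step cannot simply be carried from one core to the other: the same change on two cores in this assay, a 3.2-fold higher number (0.51 log units; beyond the scatter) from compound 2 to compound 1 and a 1.2-fold lower number (0.09 log units; within the scatter) from compound 3 to compound 4, 4.0-fold (0.60 log units) apart, beyond the scatter of two such steps. For the compounds shown here, with only one pair on each core, this does not show why the steps differ or which of them is more typical of the series.

The compounds shown leave open how an amine or a fluorine atom on this ring carbon would behave. They also leave open whether the hydroxy step on a core with a longer chain would resemble the step to compound 1 or the step to compound 4.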